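Replacing the Sulfonamide Substituent of Compound 3

The compounds below may be only part of what the source reports. "The series", "measured", "known", "first", "only" and "open" are said of these compounds alone.

Measured so far in an ADME assay on microsomes from liver (Mus musculus, strain CD-1) for metabolic stability, read by LC-MS, tested at 2 uM; on this read-out higher numbers stand for a longer-lived compound and lower numbers for a shorter-lived compound

Compound 1 `CNS(=O)(=O)c1ccccc1Nc1cc(-c2ccc3ccn(C)c3c2)c2nccnc2c1` gives 0.2 h
Compound 2 `CN1CCCC(NS(=O)(=O)c2ccccc2Nc2cc(-c3ccc4ccn(C)c4c3)c3nccnc3c2)C1` gives 0.483 h
Compound 3 `CN1CCC(NS(=O)(=O)c2ccccc2Nc2cc(-c3ccc4ccn(C)c4c3)c3nccnc3c2)C1` gives 0.667 h

Compound 3 shares the upper end of these numbers with compound 2. Their gap is a 1.4-fold higher number from compound 2 to compound 3 (0.14 log units; within the scatter) and no more, while a 3.3-fold higher number from compound 1 to compound 3 (0.52 log units; beyond the scatter) is a modest step. Compound 4 `Cn1ccc2ccc(-c3cc(Nc4ccccc4S(=O)(=O)NCC4CCOCC4)cc4nccnc34)cc21` differs from compound 3 by (oxan-4-yl)methyl in place of 1-methylpyrrolidin-3-yl on a sulfonamide nitrogen with (oxan-4-yl)methyl in place of 1-methylpyrrolidin-3-yl. Among the compounds with values here, no measured compound carries this group. The closest guide is the exchange of one cyclic group for another on that nitrogen, seen in a 1.4-fold higher number from compound 2 to compound 3 (0.14 log units; within the scatter) as a move inside the scatter. The other replacement of methyl, a 2.4-fold higher number from compound 1 to compound 2 (0.38 log units; beyond the scatter) is also modest. The expected change is therefore a 1.3-fold lower number from compound 3 to compound 4 (0.13 log units; within the scatter) and no step beyond the scatter is expected. Compound 4 is estimated at 0.5 h with an expected range from 0.2 h to 1.2 h in this assay.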

Compound 4, half-life: 0.3 h
Beside the measured number, compound 4's estimate is 1.7-fold (0.22 log units) above it; measured number inside the range.
By their numbers in this assay, from the lowest: compounds 1, 4, 2 and 3 (each within the scatter of the next, the first and the last beyond it).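

In this assay, within the data shown here, the exchange of 1-methylpyrrolidin-3-yl for (oxan-4-yl)methyl on the sulfonamide nitrogen gives a 2.2-fold lower number from compound 3 to compound 4 (0.35 log units; beyond the scatter) and is the first exchange between larger groups there to pass the scatter. Compound 4 stays within the scatter of both neighbours, with a 1.6-fold lower number from compound 2 to compound 4 (0.21 log units; within the scatter) and with a 1.5-fold higher number from compound 1 to compound 4 (0.18 log units; within the scatter) as its listed steps, so it keeps no clear lead over the methyl compound. No evidence on the cause is at hand.

On these data alone, compound 4 changes ring size, ring hetero atom and linker together, so their separate shares remain open. As far as these compounds go, a 2-(dimethylamino)ethyl chain or a carboxylic acid on this nitrogen also remains open.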